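Moving the halogen on the amide-bearing arm of compound 1

The source may hold more compounds than are shown below. What is called first, only, known or untested is meant among the compounds shown, and "the series" means these compounds.

In a functional assay on DU-145 cells (Homo sapiens) for inhibition, read by MTT assay, with a stated time of 24 h (a lower number here means a stronger inhibitor, a higher number a weaker inhibitor), compound 1 `CCOC(=O)C1=Cc2ccccc2OC1(OCc1cn(CC(=O)Nc2ccccc2Br)nn1)C(F)(F)F` gives only a limit, > 150000 nM, so no number stands for it. Among the compounds with values here, the only evidence on this point is the limit of > 150000 nM in this assay, at which 1 of the 3 values shown sits, which is where compound 1 sits. Compound 2 `CCOC(=O)C1=Cc2ccccc2OC1(OCc1cc(-c2ccc3ccccc3c2)no1)C(F)(F)F` gives 71800 nM in this assay, and compound 3 `CCOC(=O)C1=Cc2ccccc2OC1(OCc1cc(-c2cccc(C(F)(F)F)c2)no1)C(F)(F)F` gives 57300 nM. Within the data shown here, the one measured step, a 1.3-fold lower number from compound 2 to compound 3 (0.10 log units; within the scatter), lies within the scatter and concerns an aromatic carbon on an arm that compound 1 does not carry.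

Compound 4 `CCOC(=O)C1=Cc2ccccc2OC1(OCc1cn(CC(=O)Nc2cccc(Cl)c2)nn1)C(F)(F)F` differs from compound 1 by 3-chlorophenyl in place of 2-bromophenyl on an amide-type nitrogen. Among the measured compounds shown here, no measured step touches the amide-type nitrogen, and no compound with a halogen moved on that phenyl has a number. The step from compound 2 to compound 3 is the nearest comparison, a halogen-bearing phenyl replacing another aryl elsewhere, and it changed little. Compound 1 itself offers only a limit, so any move toward a measurable number would have to be large to register.

Compound 4 is therefore expected at 150000 nM, between 60000 nM and 400000 nM. The step of a number no higher from compound 1 to compound 4 (the limit leaves the size open) is expected to stay within the scatter, with a fair chance that this assay again reports only a limit for compound 4.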

Compound 4, half-maximal inhibitory concentration: 10100 nM
Beside the measured number, compound 4's estimate is 15-fold (1.17 log units) above it; the whole stated range lies above it.
By their numbers in this assay, from the lowest: compound 4; then compounds 3 and 2 (each within the scatter of the next). At a limit, above all of these: compound 1.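

Within the data shown here, the amide-bearing arm is a place where the read-out in this assay responds strongly: 3-chlorophenyl in place of 2-bromophenyl on an amide-type nitrogen gives an at least 14-fold lower number from compound 1 to compound 4 (1.17 log units; beyond the scatter), whereas the only earlier step, a 1.3-fold lower number from compound 2 to compound 3 (0.10 log units; within the scatter), lay on a different arm and stayed within the scatter. As far as these compounds go, compound 1 is held only by a limit, so the size of the new step is a minimum and its upper end stays open: the limit of > 150000 nM in this assay, at which 1 of the 4 values shown sits. The change replaces the halogen and alters its position on the phenyl in a single step, so the gain cannot be assigned to either alone.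

The compounds shown leave that split unresolved, and a 3-bromophenyl or a 2-chlorophenyl on the same amide-type nitrogen would separate the identity of the halogen from its place on the ring. Also open, from the compounds shown here alone, is how far the number at this position moves with an unsubstituted phenyl, or with a phenyl carrying an amine or a carboxylic acid in place of the chlorine of compound 4.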